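The source may report more compounds than this note shows. Statements on the series, on what has been measured and on what is new or still open speak of the compounds shown alone.

Measured so far in a functional assay on the whole organism (strain Sprague-Dawley) for inhibition, with Rattus norvegicus as the target, with a stated time of 10 min; a lower number here means that less compound is needed, a higher number that more compound is needed for the effect:

Compound 1 `CCCOc1ccccc1-c1ncc(C(=O)O)c(=O)[nH]1` gives 0.9 mg/kg.
Compound 2 `O=C(O)c1cnc(-c2ccc(Cl)cc2)[nH]c1=O` gives 5 mg/kg.
Compound 3 `CCCOc1ccccc1-c1ncc(C(=O)OCC)c(=O)[nH]1` gives 5 mg/kg.

Compound 3 differs from compound 1 in one place only: ethyl in place of hydrogen on an oxygen next to a carbonyl group. That single change produced a 5.6-fold higher number from compound 1 to compound 3 (0.74 log units; beyond the scatter), so the acid form needs less compound than its ester. Compound 2 and compound 3 stand level at the digits given, and the difference between the cores of compound 1 and compound 2 is not broken down here.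

Compound 4 `CCOC(=O)c1cnc(-c2ccc(Cl)cc2)[nH]c1=O` has not yet been measured. It differs from compound 2 by ethyl in place of hydrogen on an oxygen next to a carbonyl group, which is the same change that turns compound 1 into compound 3, made at the same place but on the core of compound 2. Because the earlier step was a 5.6-fold higher number from compound 1 to compound 3 (0.74 log units; beyond the scatter), the number for compound 4 is expected to rise by about a 5.6-fold higher number from compound 2 to compound 4 (0.75 log units; beyond the scatter) from that of compound 2. The expectation rests on a single precedent, so it is held loosely. Compound 4 is therefore estimated at 28 mg/kg in this assay, most likely between 10 mg/kg and 80 mg/kg.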

Compound 4, dose for 50% inhibition: > 30 mg/kg
Compound 4: no number, only a limit (the forecaster's own chance of this, stated with the estimate: 15%); at least 1.0-fold (0.02 log units) between middle value and limit.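

In this assay compound 4 gives > 30 mg/kg, which is a limit of the assay and not a number. Read against compound 2, this gives an at least 6.0-fold higher number from compound 2 to compound 4 (0.77 log units; beyond the scatter), so replacing carboxy with ethoxycarbonyl raises the number on both cores shown, and the direction of the change carries over from one core to the other: the same change on two cores in this assay, a 5.6-fold higher number (0.74 log units; beyond the scatter) from compound 1 to compound 3 and an at least 6.0-fold higher number (0.77 log units; beyond the scatter) from compound 2 to compound 4; the limit leaves it open whether they differ What this does not show is whether the size of the change carries over too, since the true value of compound 4 could lie anywhere beyond the limit and the step on this core has no upper end.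

The compounds shown leave open whether other groups on that oxygen, such as a methyl or a longer chain, would raise the number to a similar degree as ethyl. They also leave open how an amide in place of the carboxylic acid would fare on either core, and whether the same change behaves alike on cores beyond these.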